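This account rests on a few compounds, and the source may have more. Where it says the series, first, only, none or still open, it means among the compounds named here.

Measured compounds:
compound 1, `COc1ccc(C2=NN(C3=NC(=O)/C(=C4\C(=O)Nc5ccccc54)S3)C(c3ccc(OC)cc3)C2)cc1`, 100000 nM
compound 2, `COc1ccc(C2CC(c3ccc4ccccc4c3)=NN2C2=NC(=O)/C(=C3\C(=O)Nc4ccccc43)S2)cc1`, 360 nM
compound 3, `COc1ccc(C2=NN(C3=NC(=O)/C(=C4\C(=O)Nc5ccccc54)S3)C(c3ccc(Cl)cc3)C2)cc1`, 100000 nM

The three compounds share one core and differ at two places on it. In a functional assay on cells (Cancer cell lines, Homo sapiens) for cytotoxicity, read by sulforhodamine B assay, with a stated time of 48 h (on this read-out higher numbers stand for weaker inhibition of growth and lower numbers for stronger inhibition of growth), compound 1 gives 100000 nM. Compound 2 differs from compound 1 by naphthalen-2-yl in place of 4-methoxyphenyl on a carbon with a double bond to nitrogen, and in this assay compound 2 gives 360 nM, a step of a 280-fold lower number from compound 1 to compound 2 (2.44 log units; beyond the scatter). Compound 3 differs from compound 1 by chloro in place of methoxy on an aromatic carbon, and in this assay compound 3 gives 100000 nM, which is no change at the digits printed from compound 1 to compound 3 (within the scatter). Compound 3 and compound 1 therefore stand level and are together the highest of the three numbers.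

Compound 4, `O=C1N=C(N2N=C(c3ccc4ccccc4c3)CC2c2ccc(Cl)cc2)S/C1=C1/C(=O)Nc2ccccc21`, has not been measured. It differs from compound 3 by naphthalen-2-yl in place of 4-methoxyphenyl on a carbon with a double bond to nitrogen. Among the compounds with values here, this is the same kind of change as the one from compound 1 to compound 2, but not the same: the ring atom two ring bonds from the place bears a 4-chlorophenyl group (7 heavy atoms) in compound 3 and compound 4, whereas it bears a 4-methoxyphenyl group (8 heavy atoms) in compound 1 and compound 2. The expectation for compound 4 rests on a 280-fold lower number from compound 1 to compound 2 (2.44 log units; beyond the scatter) together with no change at the digits printed from compound 1 to compound 3 (within the scatter), the latter suggesting that the chloro and methoxy variants behave alike on this read-out. The step from compound 3 to compound 4 is expected to be a 250-fold lower number from compound 3 to compound 4 (2.40 log units; beyond the scatter). Within the data shown here, compound 4 is accordingly estimated at 400 nM, with a range from 100 nM to 2000 nM, given that only one example of this change is available.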

Compound 4, concentration for 50% growth inhibition: 400 nM
Compound 4: middle estimate and measured number agree at the digits printed, and the stated range covers the measured number.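

In this assay, naphthalen-2-yl in place of 4-methoxyphenyl gives a 250-fold lower number from compound 3 to compound 4 (2.40 log units; beyond the scatter), and this step on the chloro-bearing core matches the earlier step on the methoxy-bearing core: the same change on two cores in this assay, a 280-fold lower number (2.44 log units; beyond the scatter) from compound 1 to compound 2 and a 250-fold lower number (2.40 log units; beyond the scatter) from compound 3 to compound 4, 1.1-fold (0.05 log units) apart, within the scatter of two such steps Chloro in place of methoxy gives a 1.1-fold higher number from compound 2 to compound 4 (0.05 log units; within the scatter), so this change also reads the same whichever of the two groups stands on the carbon with a double bond to nitrogen: the same change on two cores in this assay, no change at the digits printed (within the scatter) from compound 1 to compound 3 and a 1.1-fold higher number (0.05 log units; within the scatter) from compound 2 to compound 4, 1.1-fold (0.05 log units) apart, within the scatter of two such steps Among these four compounds, then, each change carries from one core to the other, and the naphthalen-2-yl group marks the large step while the chloro and methoxy variants stay level, but this rests on only two pairs for each change and does not show that the agreement would hold for any other group or core, nor does it explain the size of the step.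

The compounds shown leave open whether a plain phenyl group, or a longer chain, at the carbon with a double bond to nitrogen would give a number like that of the naphthalen-2-yl compounds or like that of the 4-methoxyphenyl compounds. They also leave open whether an amine or a carboxylic acid on the naphthalen-2-yl group, or a fluoro or hydroxy group in place of the chloro, would leave the number unchanged.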